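The source may hold more compounds than are shown below. What is called first, only, known or untested is meant among the compounds shown, and "the series" means these compounds.

Measured so far:
compound 1, `Cc1ccc2nc(N3CCCc4ccc(F)cc4C3)cc(NCC3(N)COC3)c2c1`, which gives 204 mL/min/kg in an ADME assay on microsomes from liver (Mus musculus) for metabolic stability; a lower number here means slower removal, a higher number faster removal of the compound
compound 2, `NCCNc1cc(N2CCCc3ccccc3C2)nc2ccccc12`, which gives 19 mL/min/kg in this assay

Compound 1 stands highest of the two numbers in this assay; its nearest neighbour is compound 2, whose number lies lower by a gap that is beyond the usual scatter. Among the measured compounds shown here, no pair of measured compounds differs in a single place, so no measured step is available as a guide for the compound that is still to be tested.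

Compound 3, `Cc1ccc2nc(N3CCCc4ccc(F)cc4C3)cc(NC3(CN)COC3)c2c1`, differs from compound 1 by 3-(aminomethyl)oxetan-3-yl in place of (3-aminooxetan-3-yl)methyl on a nitrogen on an aromatic ring; the two have the same atoms, joined differently. For the measured compounds named here, with only a rearrangement of the same atoms and no measured step to lean on, the step of a 1.3-fold lower number from compound 1 to compound 3 (0.11 log units; within the scatter) is expected to be small, in no firm direction, and probably within the scatter. Compound 3 is accordingly estimated at 160 mL/min/kg, with a range from 60 mL/min/kg to 420 mL/min/kg.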

Compound 3, clearance: 23 mL/min/kg
Estimate against measurement, compound 3: 7.0-fold (0.84 log units) above; the measured number lies below the stated range.
By their numbers in this assay, from the lowest: compounds 2 and 3 (each within the scatter of the next); then compound 1.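

In this assay the series now holds a measured change in a single place: an 8.9-fold lower number from compound 1 to compound 3 (0.95 log units; beyond the scatter) comes with 3-(aminomethyl)oxetan-3-yl in place of (3-aminooxetan-3-yl)methyl on a nitrogen on an aromatic ring. This step lies beyond the scatter, so at this position the number depends on how the atoms of the group are joined, although the two groups match in heavy atoms, ring, donors and acceptors. Nothing shown here accounts for the step.

This single pair leaves open whether the same rearrangement would give a step of similar size on another core. It also leaves open where the number would fall with a longer chain carrying the amine, or with a hydroxyl group in place of the amine.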